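Three Measured Phenolic Enones and a Fourth Still Unmeasured

This account rests on a few compounds, and the source may have more. Where it says the series, first, only, none or still open, it means among the compounds named here.

Measured compounds in an ADME assay on PC-12 cells (Rattus norvegicus) for cytotoxicity, read by WST assay, with a stated time of 24 h; a lower number here means that less compound is tolerated, a higher number that more compound is tolerated:
compound 1 `O=C(/C=C/c1cccc(O)c1)CC(=O)/C=C/c1cccc(O)c1O` gives 38000 nM
compound 2 `O=C(/C=C/c1ccc(O)cc1)CC(=O)/C=C/c1cccc(O)c1O` gives 8500 nM
compound 3 `O=C(/C=C/c1cccc(O)c1)/C=C/c1cccc(O)c1O` gives 46000 nM

Compound 1 and compound 2 share one core and differ in a single place: 4-hydroxyphenyl in place of 3-hydroxyphenyl on a double-bonded chain carbon bound to a double-bonded chain carbon. This change gave a 4.5-fold lower number from compound 1 to compound 2 (0.65 log units; beyond the scatter), so compound 2 is tolerated at a lower concentration than compound 1. Compound 3 has a different core from compound 1; the difference between the two cores is not broken down here. In this assay compound 3 and compound 1 lie within the scatter of each other, while compound 3 and compound 2 lie beyond it. Compound 4 `O=C(/C=C/c1ccc(O)cc1)/C=C/c1cccc(O)c1O` has not yet been measured. It differs from compound 3 in exactly the way compound 2 differs from compound 1: 4-hydroxyphenyl in place of 3-hydroxyphenyl on a double-bonded chain carbon bound to a double-bonded chain carbon. Because the same change at the same place gave a 4.5-fold lower number from compound 1 to compound 2 (0.65 log units; beyond the scatter), a step of similar size is expected from compound 3 to compound 4, namely a 4.6-fold lower number from compound 3 to compound 4 (0.66 log units; beyond the scatter). That expectation rests on a single earlier pair, so the range is kept wide. Compound 4 is therefore estimated at 10000 nM, with a likely span from 4000 nM to 25000 nM.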

Compound 4, half-maximal cytotoxic concentration: 12000 nM
For compound 4 the middle estimate is 1.2-fold (0.08 log units) below the measured one, and the stated range covers the measured number.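

In this assay, placing 4-hydroxyphenyl where 3-hydroxyphenyl stood, on a double-bonded chain carbon bound to a double-bonded chain carbon, gives a 3.8-fold lower number from compound 3 to compound 4 (0.58 log units; beyond the scatter). Less compound is therefore tolerated after this change on both cores shown, and the size of the step carries over from one core to the other: the same change on two cores in this assay, a 4.5-fold lower number (0.65 log units; beyond the scatter) from compound 1 to compound 2 and a 3.8-fold lower number (0.58 log units; beyond the scatter) from compound 3 to compound 4, 1.2-fold (0.07 log units) apart, within the scatter of two such steps. This agreement rests on just two pairs of compounds in a single cell assay, so it does not show that the change would behave the same way on any further core, and it does not explain why the swap lowers the number.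

The compounds shown keep a hydroxyl group on the ring that changes, so they leave open what an amine or a carboxylic acid in its place would do to the tolerated concentration. They also leave open whether the step keeps its size on a core with a longer chain joining the two rings.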